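A few compounds are considered here, and "the series" means these few. Any claim that something is new, unique, unknown or untested is made for them only; others in the source may bear on it.

The measured compounds so far:

Compound 1, `Cc1nn2c(-c3nc4cc(Cl)ccc4[nH]3)c(-c3ccccc3)nc2s1`: in a functional assay on A549 cells (Homo sapiens) for antiproliferative activity, read by MTT assay (a higher number here means a weaker inhibitor, a lower number a stronger inhibitor), compound 1 gives 16900 nM.
Compound 2, `Cc1nn2c(-c3nc4ccccc4[nH]3)c(-c3ccccc3)nc2s1`: compound 2 gives 16600 nM.
Compound 3, `Cc1nn2c(-c3nc4cc(Cl)ccc4[nH]3)c(-c3ccc(F)cc3)nc2s1`: compound 3 gives 10200 nM.

All three share one core and differ only in small groups on their outer rings. Compound 1 and compound 2 differ by hydrogen in place of chloro on an aromatic carbon, and that change made a 1.0-fold lower number from compound 1 to compound 2 (0.01 log units; within the scatter). Compound 1 and compound 3 differ by fluoro in place of hydrogen on an aromatic carbon, with a 1.7-fold lower number from compound 1 to compound 3 (0.22 log units; within the scatter).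

Compound 4, `Cc1nn2c(-c3nc4ccccc4[nH]3)c(-c3ccc(F)cc3)nc2s1`, has not yet been measured. It differs from compound 3 by hydrogen in place of chloro on an aromatic carbon, the same change that separates compound 1 from compound 2, at the same place. Since the values of compound 1 and compound 2 lie within the scatter of each other, the earlier step gives no sign that this change moves the number. Compound 4 is therefore expected to land close to compound 3, with an expected step of a 1.0-fold higher number from compound 3 to compound 4 (0.01 log units; within the scatter), because a 1.0-fold lower number from compound 1 to compound 2 (0.01 log units; within the scatter) stayed within the scatter. The estimate for compound 4 in this assay is 10500 nM, expected to fall between 5500 nM and 20000 nM.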

Compound 4, half-maximal inhibitory concentration: > 30000 nM
Compound 4 ended at the assay's limit; the forecaster's own chance of this, stated with the estimate: 3%; at least 2.8-fold (0.45 log units) between middle value and limit.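

> 30000 nM is the reading for compound 4 in this assay, and it is a limit of the assay, not a number. Putting hydrogen in place of chloro did not behave alike on the two cores, giving an at least 2.9-fold higher number from compound 3 to compound 4 (0.46 log units; beyond the scatter) once the fluoro is present, so the earlier flat step did not carry over: the same change on two cores in this assay, a 1.0-fold lower number (0.01 log units; within the scatter) from compound 1 to compound 2 and an at least 2.9-fold higher number (0.46 log units; beyond the scatter) from compound 3 to compound 4, at least 2.9-fold (0.47 log units) apart, beyond the scatter of two such steps. Read the other way round, fluoro in place of hydrogen gives an at least 1.8-fold higher number from compound 2 to compound 4 (0.25 log units; that floor lies within the scatter), and although that floor alone is small, these steps show only that a change seen on one core need not repeat on another, not how large the true gap is or why it arises: the same change on two cores in this assay, a 1.7-fold lower number (0.22 log units; within the scatter) from compound 1 to compound 3 and an at least 1.8-fold higher number (0.25 log units; that floor lies within the scatter) from compound 2 to compound 4, at least 2.9-fold (0.47 log units) apart, beyond the scatter of two such steps.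

As far as these compounds go, the exact value of compound 4 stays open, and these four compounds form a single small set from which no rule for the wider series follows. From the compounds shown here alone, it is also open how other groups in place of the chloro, such as bromo, methyl or an amine, would behave with and without the fluoro.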